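Replacing 4-hydroxyphenyl with 3,4,5-trimethoxyphenyl on compound 2

This account rests on a few compounds, and the source may have more. Where it says the series, first, only, none or still open, it means among the compounds named here.

Among the compounds with values here, compound 1 `CCN(CC)CCCn1c(=O)/c(=C/c2ccc(O)cc2)s/c1=C1\C(=O)Nc2ccc(Cl)cc21` and compound 2 `CCN(CC)CCCn1c(=O)/c(=C/c2ccc(O)cc2)s/c1=C1/C(=O)Nc2ccc(Cl)cc21` form the only measured pair so far. In a functional assay on K562/Adr cells (Homo sapiens) for cytotoxicity, read by sulforhodamine B assay, with a stated time of 48 h (on this read-out lower numbers stand for stronger inhibition and higher numbers for weaker inhibition), compound 1 gives 48800 nM, and compound 2 gives 48800 nM, so compound 2 stands level with its partner. Within the data shown here, the single measured step shows no change at the digits printed from compound 1 to compound 2 (within the scatter), and its scope is limited by the fact that compounds 1 and 2 differ only in the configuration as drawn.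

Compound 3 `CCN(CC)CCCn1c(=O)/c(=C/c2cc(OC)c(OC)c(OC)c2)s/c1=C1/C(=O)Nc2ccc(Cl)cc21` keeps the shared core and the double bond as drawn in compound 2. The change is 3,4,5-trimethoxyphenyl in place of 4-hydroxyphenyl on a double-bonded chain carbon bound to an aromatic carbon.

The measured step involves no change of this group, so it offers no direct guide to the size of the new step. The estimate is therefore a cautious one, with a wide range. Compound 2, at 48800 nM, sits high on the scale of this assay, which leaves room for a fall. The expected change is a 2.2-fold lower number from compound 2 to compound 3 (0.35 log units; beyond the scatter), a modest move towards stronger inhibition. For compound 3 the estimated value is 22000 nM, with an expected range from 6000 nM to 70000 nM.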

Compound 3, half-maximal inhibitory concentration: 1650 nM
Compound 3: the middle estimate sits 13-fold (1.12 log units) above what was measured; measured number below the stated range.
By their numbers in this assay, from the lowest: compound 3; then compounds 1 and 2 (each within the scatter of the next).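

This position, on a double-bonded chain carbon bound to an aromatic carbon, is far from indifferent: in this assay, 3,4,5-trimethoxyphenyl in place of 4-hydroxyphenyl gives a 30-fold lower number from compound 2 to compound 3 (1.47 log units; beyond the scatter). A change of aromatic group here can therefore move this read-out strongly, whereas the change of drawn configuration in the earlier pair left the printed value unmoved. That pair could not show the effect of this group, for one plain reason: the fact that compounds 1 and 2 differ only in the configuration as drawn.

The swap alters several things at once: the hydroxyl and its hydrogen-bond donor leave, methoxy groups and more hydrogen-bond acceptors enter, and the group gains heavy atoms, so this single step cannot tell which of these changes matters. As far as these compounds go, a plain phenyl ring or a phenyl ring carrying a single methoxy group at this place would help to separate them, and it remains open whether 3,4,5-trimethoxyphenyl gives the same gain with the double bond drawn as in compound 1.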